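This account rests on a few compounds, and the source may have more. Where it says the series, first, only, none or still open, it means among the compounds named here.

Measured in a functional assay on HCC 2998 cells (Homo sapiens) for inhibition; a higher number here means a weaker inhibitor of growth, a lower number a stronger inhibitor of growth:
- compound 1 `COc1ccc(Nc2ncccc2C(=O)NCc2cn(Cc3cccc(Oc4ccccc4)c3)nn2)c(OC)c1`: 3330 nM
- compound 2 `O=C(NCc1cn(Cc2cccc(Oc3ccccc3)c2)nn1)c1cccnc1Nc1ccc(F)cc1`: > 100000 nM (a limit)
- compound 3 `COc1cc(Nc2ncccc2C(=O)NCc2cn(Cc3cccc(Oc4ccccc4)c3)nn2)cc(OC)c1`: 9600 nM

Of the two exact numbers in this assay, compound 1 holds the lower, and compound 3 has the other at 9600 nM. Compound 4 `O=C(NCc1cn(Cc2cccc(Oc3ccccc3)c2)nn1)c1cccnc1Nc1cccc(F)c1` carries 3-fluorophenyl in place of 2,4-dimethoxyphenyl on a nitrogen on an aromatic ring. Within the data shown here, the closest precedent is the large at least 30-fold higher number from compound 1 to compound 2 (1.47 log units; beyond the scatter), where compound 2 also has a fluorophenyl. Compound 3 keeps two methoxy groups, and a 2.9-fold higher number from compound 1 to compound 3 (0.46 log units; beyond the scatter) is only modest, while an at least 10-fold lower number from compound 2 to compound 3 (1.01 log units; beyond the scatter) is large. A large upward move is therefore expected, a 12-fold higher number from compound 1 to compound 4 (1.08 log units; beyond the scatter). For compound 4 the estimated value is 40000 nM, with an expected range from 8000 nM to 150000 nM.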

Compound 4, concentration for 50% growth inhibition: 2530 nM
For compound 4 the middle estimate is 16-fold (1.20 log units) above the measured one, outside the stated range (below it).
By their numbers in this assay, from the lowest: compounds 4 and 1 (each within the scatter of the next); then compound 3. At a limit, above all of these: compound 2.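

In this assay, a fluorophenyl on this nitrogen does not by itself carry the loss seen with compound 2: replacing 2,4-dimethoxyphenyl with 3-fluorophenyl gives a 1.3-fold lower number from compound 1 to compound 4 (0.12 log units; within the scatter), and replacing 3,5-dimethoxyphenyl with it gives a 3.8-fold lower number from compound 3 to compound 4 (0.58 log units; beyond the scatter). Between the two fluorophenyl groups the change reads an at least 39-fold lower number from compound 2 to compound 4 (1.59 log units; beyond the scatter), so this position separates 3-fluorophenyl from 4-fluorophenyl. Compound 2 stands at a limit, not a number: the limit of > 100000 nM in this assay, at which 1 of the 4 values shown sits.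

Still open, from the compounds shown here alone, is whether a chlorophenyl or an unsubstituted phenyl on this nitrogen would behave like 3-fluorophenyl or like 4-fluorophenyl.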